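The compounds below may be only part of what the source reports. "The series", "measured", "known", "first", "only" and "open" are said of these compounds alone.

In a functional assay on NALM-6 cells (Homo sapiens) for cytotoxicity, read by luminescence and CellTiter-Glo, with a stated time of 3 days (on this read-out lower numbers stand for stronger inhibition and higher numbers for weaker inhibition), compound 3 `O=C(Nc1ccc(C(F)(F)F)cc1)c1cc(Cl)ccc1O` gives 1210 nM. That number is level, at the digits shown, with compound 2 `O=C(Nc1ccc(OC(F)(F)F)cc1)c1cc(F)ccc1O`, which gives 1210 nM in this assay; together the two stand as the highest of the three numbers measured so far. For the measured compounds named here, compound 1 `O=C(Nc1ccc(C(F)(F)F)cc1)c1cc(Cl)c(-c2ccccc2)cc1O` gives 800 nM in this assay, and the only single-point step among the measured compounds, a 1.5-fold higher number from compound 1 to compound 3 (0.18 log units; within the scatter), lies within the scatter.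

Compound 4 `O=C(Nc1ccc(C(F)(F)F)cc1)c1cc(F)ccc1O` differs from compound 3 in one place: fluoro in place of chloro on an aromatic carbon. Going by the values given here, no measured step exchanges these two halogens on the shared core, so none bears directly on it. Compound 2 also carries a fluoro, and its value of 1210 nM in this assay matches that of compound 3, but compound 2 differs from compound 4 in the group on the ring attached to the amide nitrogen as well, so it gives no clean guide. Among the compounds with values here, the one measured step, a 1.5-fold higher number from compound 1 to compound 3 (0.18 log units; within the scatter), shows that a far larger change than a halogen swap stayed within the scatter here.

The step from compound 3 to compound 4 is therefore expected to be small, a 1.0-fold lower number from compound 3 to compound 4 (0.00 log units; within the scatter), with no clear direction. Compound 4 is estimated at 1200 nM in this assay, with a range of 600 nM to 2400 nM.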

Compound 4, half-maximal inhibitory concentration: 2090 nM
Compound 4: the middle estimate sits 1.7-fold (0.24 log units) below what was measured, within the range that was stated.
By their numbers in this assay, from the lowest: compounds 1, 2, 3 and 4 (each within the scatter of the next, the first and the last beyond it).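

For the compounds shown here, compound 3 and compound 4 give the first direct reading of the halogen at this position, meta to a large group and para to a hydroxy group. In this assay, fluoro in place of chloro gives a 1.7-fold higher number from compound 3 to compound 4 (0.24 log units; within the scatter), so this exchange does not separate the two compounds, and the same holds on the fluoro series for the other group, where trifluoromethyl in place of trifluoromethoxy gives a 1.7-fold higher number from compound 2 to compound 4 (0.24 log units; within the scatter). Across these compounds, then, neither single exchange produces a step larger than the scatter, and nothing measured here gives a reason for where these numbers fall.

The compounds shown leave open whether a group of a different kind at this position, such as an amine, a methoxy group or a nitrile, would produce a step beyond the scatter. They also leave open what a carboxylic acid in place of the hydroxy group would do, and whether the phenyl group of compound 1 would give the same small step on the fluoro compound.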